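The compounds below may be only part of what the source reports. "The series", "measured", "known", "first", "only" and "open" are said of these compounds alone.

Three related compounds have been examined in an ADME assay on Vero cells (Chlorocebus sabaeus) for cytotoxicity, read by MTT assay, with a stated time of 72 h (a higher number here means that more compound is tolerated, a lower number that less compound is tolerated), and all three share the same core, a chain with a carbonyl flanked by double bonds and an aromatic ring at each end. Compound 1 `COc1ccc(/C=C(\C)C(=O)/C=C/c2ccc(Cl)cc2)cc1` gives 87000 nM in this assay. Compound 2 `COc1ccc(/C=C(\C)C(=O)/C=C/c2cccc(Cl)c2Cl)cc1` gives 119000 nM in this assay, which lies within the usual scatter of compound 1, so the two cannot be told apart. Compound 3 `CC/C(=C\c1ccc(Cl)cc1)C(=O)/C=C/c1ccccc1Br` gives 24400 nM in this assay, and this number lies beyond the scatter below compound 1. Compound 1 thus stands second highest of the three numbers shown, close to compound 2 and clearly apart from compound 3.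

Compound 4 `COc1ccc(/C=C(\C)C(=O)/C=C/c2ccccc2Br)cc1` has not yet been measured in this assay. It differs from compound 1 in one place: 2-bromophenyl in place of 4-chlorophenyl on a double-bonded chain carbon bound to a double-bonded chain carbon. No measured pair differs by exactly this change, so any expectation rests on the three numbers shown. Because compound 3, which also carries a 2-bromophenyl, gives 24400 nM, a modest downward step is expected, though compound 3 differs in more than one place, so the size is uncertain. The estimated step from compound 1 to compound 4 is a 1.7-fold lower number from compound 1 to compound 4 (0.24 log units; within the scatter). Compound 4 is therefore expected to give about 50000 nM in this assay, within a range from 20000 nM to 120000 nM.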

Compound 4, half-maximal cytotoxic concentration: 71000 nM
The estimate for compound 4 lay 1.4-fold (0.15 log units) below the measured number; measured number inside the range.
By their numbers in this assay, from the lowest: compound 3; then compounds 4, 1 and 2 (each within the scatter of the next).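

Within the data shown here, this result gives the first comparison in this assay between two compounds that differ in one place, and it shows a 1.2-fold lower number from compound 1 to compound 4 (0.09 log units; within the scatter). On this double-bonded chain carbon, with the rest of compound 1 unchanged, 2-bromophenyl and 4-chlorophenyl therefore cannot be told apart in this assay, so this change brings no detectable shift in how much compound is tolerated. No measurement of any property of these groups is available to account for this result.

The change alters both the halogen and where it sits on the ring, and the compounds shown cannot separate these two differences. They also leave open how the number would respond to a quite different group on this ring, such as an amine or a carboxylic acid.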